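The source may hold more compounds than are shown below. What is called first, only, known or untested is meant among the compounds shown, and "the series" means these compounds.

In a functional assay on HCT-116 cells (Homo sapiens) for inhibition, read by CCK-8 assay, with a stated time of 48 h (a lower number here means a stronger inhibitor, a higher number a weaker inhibitor), compound 1 (`COc1ccc(CN(C(=O)CSC(=S)N2CCN(C(=O)OC(C)(C)C)CC2)c2cc(OC)c(OC)c(OC)c2)cc1`) gives 620 nM and compound 2 (`COc1ccc(CN(C(=O)CSC(=S)N2CCN(Cc3ccc(C(C)(C)C)cc3)CC2)c2cc(OC)c(OC)c(OC)c2)cc1`) gives 6890 nM while compound 3 (`COc1ccc(CN(C(=O)CSC(=S)N2CCCC2)c2cc(OC)c(OC)c(OC)c2)cc1`) gives 4970 nM in this read-out. Compound 3 thus lies within the scatter of compound 2 and well beyond the scatter from compound 1. Compound 4 (`COc1ccc(CN(C(=O)CSC(=S)N2CCCc3cc(OC)ccc32)c2cc(OC)c(OC)c(OC)c2)cc1`) has 6-methoxy-1,2,3,4-tetrahydroquinolin-1-yl in place of pyrrolidin-1-yl on a thiocarbonyl carbon. For the measured compounds named here, the only measured step, an 11-fold higher number from compound 1 to compound 2 (1.05 log units; beyond the scatter) as a large change, is a different exchange, on an amine nitrogen in a ring, so it shows only that large steps occur. A modest move is expected, with weak confidence in its direction, namely a 2.0-fold lower number from compound 3 to compound 4 (0.30 log units; within the scatter) as estimated in this assay here. For compound 4 the estimate is 2500 nM with an expected range from 600 nM to 9000 nM overall.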

Compound 4, half-maximal inhibitory concentration: > 20000 nM
Compound 4: a limit, no number; the forecaster's own chance of this, stated with the estimate: 5%; middle value at least 8.0-fold (0.90 log units) from the limit.
By their numbers in this assay, from the lowest: compound 1; then compounds 3 and 2 (each within the scatter of the next). At a limit, above all of these: compound 4.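

Exchange on a thiocarbonyl carbon is not neutral in this assay: 6-methoxy-1,2,3,4-tetrahydroquinolin-1-yl in place of pyrrolidin-1-yl gives an at least 4.0-fold higher number from compound 3 to compound 4 (0.60 log units; beyond the scatter). The earlier compounds shown here showed a step only on an amine nitrogen in a ring. Compound 4 stands at > 20000 nM, which is a limit and not a number, so the full size of this step stays unread: the limit of > 20000 nM in this assay, at which 1 of the 4 values shown sits.

Still open, on these data alone, is whether the methoxy group or the larger ring system goes with this step. Unsubstituted 1,2,3,4-tetrahydroquinolin-1-yl and a plain piperidin-1-yl at this place would separate the two.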